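Swapping (4-chlorophenyl)amino for (piperidin-1-yl)methyl on a carbonyl

This account rests on a few compounds, and the source may have more. Where it says the series, first, only, none or still open, it means among the compounds named here.

Compounds measured in a functional assay (strain AB) with Danio rerio as the target, read by microscopy, with a stated time of 1 h; a higher number here means that more compound is needed for the effect, a lower number that less compound is needed:
compound 1 `CCN1CCc2c(sc(NC(=O)Nc3ccc(Cl)cc3)c2C(N)=O)C1` gives 3120 nM
compound 2 `NC(=O)c1c(NC(=O)Nc2ccc(Cl)cc2)sc2c1CCN(CC1CCCCC1)C2` gives 1890 nM
compound 3 `CCN1CCc2c(sc(NC(=O)Nc3ccc(Cl)cc3Cl)c2C(N)=O)C1` gives 11500 nM

Among these three numbers compound 1 stands second highest. Its nearest neighbour is compound 2, reached by a 1.7-fold lower number from compound 1 to compound 2 (0.22 log units; within the scatter), a difference within the scatter. The furthest is compound 3, reached by a 3.7-fold higher number from compound 1 to compound 3 (0.57 log units; beyond the scatter), a modest step beyond the scatter.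

Compound 4 `CCN1CCc2c(sc(NC(=O)CN3CCCCC3)c2C(N)=O)C1` has not yet been measured in this assay. It differs from compound 1 as follows: (piperidin-1-yl)methyl in place of (4-chlorophenyl)amino on a carbonyl carbon. Neither measured step touches this part of the molecule. The step from compound 1 to compound 2 changes the group on the amine nitrogen in the ring, and the step from compound 1 to compound 3 adds a chloro to the very aromatic ring that now leaves. That the ring responds to a single chloro suggests this region matters, but nothing shown predicts what its complete replacement does.

Among the measured compounds shown here, with no bearing step, compound 4 is expected to show a 2.6-fold higher number from compound 1 to compound 4 (0.41 log units; beyond the scatter), a change that may well exceed the scatter in either direction. The estimate for compound 4 is 8000 nM, within a range from 2000 nM to 40000 nM.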

Compound 4, half-maximal effective concentration: > 25000 nM
Compound 4: a limit, no number; the forecaster's own chance of this, stated with the estimate: 20%; middle value at least 3.1-fold (0.49 log units) away from the limit.
By their numbers in this assay, from the lowest: compounds 2 and 1 (each within the scatter of the next); then compound 3. At a limit, above all of these: compound 4.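

In this assay compound 4 sits at a limit of the assay and has no number: the limit of > 25000 nM in this assay, at which 1 of the 4 values shown sits. Compound 1, compound 2 and compound 3 all keep a chlorinated phenylamino group on the carbonyl carbon, so they showed only what a chloro on that ring or a change on the ring amine does, whereas here the whole group is replaced, giving an at least 8.0-fold higher number from compound 1 to compound 4 (0.90 log units; beyond the scatter). From the compounds shown here alone, the (4-chlorophenyl)amino group therefore cannot be exchanged for (piperidin-1-yl)methyl without a clear loss, a step beyond the scatter whose full size stays unknown.

The exchange removes the aromatic ring and the hydrogen-bond donor and adds the methylene and the piperidine together, so this single step cannot separate their contributions. Going by these compounds, whether a cyclohexylamino or a benzyl group on this carbonyl carbon would hold the number near that of compound 1 remains open.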